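Working notes: from compound 3 to compound 4

This account rests on a few compounds, and the source may have more. Where it says the series, first, only, none or still open, it means among the compounds named here.

In a functional assay on HepG2 cells (Homo sapiens) for cytotoxicity, read by MTT assay, with a stated time of 72 h (a lower number here means a stronger inhibitor, a higher number a weaker inhibitor), the measured compounds read as follows:
compound 1 `COc1cc2ncnc(Nc3ccc(F)c(Cl)c3)c2cc1NC(=O)N/N=C/c1ccc(F)cc1` gives 31100 nM
compound 2 `COc1cc2ncnc(Nc3ccc(F)c(Cl)c3)c2cc1NC(=O)N/N=C/c1ccc([N+](=O)[O-])cc1` gives 34100 nM
compound 3 `COc1ccc(/C=N/NC(=O)Nc2cc3c(Nc4ccc(F)c(Cl)c4)ncnc3cc2OC)cc1` gives 21300 nM

Compound 3 is not separated from the other two measured compounds (a 1.5-fold lower number from compound 1 to compound 3 (0.16 log units; within the scatter); a 1.6-fold lower number from compound 2 to compound 3 (0.20 log units; within the scatter)). The next change, to compound 4 `COc1cc2ncnc(Nc3ccc(F)c(Cl)c3)c2cc1NC(=O)N/N=C/c1cc(Br)c(O)c(Br)c1`, is 3,5-dibromo-4-hydroxyphenyl in place of 4-methoxyphenyl on a carbon with a double bond to nitrogen.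

For the measured compounds named here, the steps that bear on this are the three swaps of one group on an aromatic carbon (a 1.1-fold higher number from compound 1 to compound 2 (0.04 log units; within the scatter); a 1.5-fold lower number from compound 1 to compound 3 (0.16 log units; within the scatter); a 1.6-fold lower number from compound 2 to compound 3 (0.20 log units; within the scatter)). All three stay within the scatter, across fluoro, nitro and methoxy. Going by the values given here, no measured compound carries the entering group, so this support is indirect and the range is kept wide. No step beyond the scatter is therefore expected in this assay. The estimated step is small (a 1.1-fold lower number from compound 3 to compound 4 (0.03 log units; within the scatter)). For compound 4 the expected value is 20000 nM (estimated range 8000 nM to 45000 nM).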

Compound 4, half-maximal inhibitory concentration: 36800 nM
Estimate against measurement, compound 4: 1.8-fold (0.26 log units) below; the range from low to high includes it.
By their numbers in this assay, from the lowest: compounds 3, 1, 2 and 4 (each within the scatter of the next).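

In this assay, for the compounds shown here, the position on a carbon with a double bond to nitrogen now tolerates a larger change than the single-group swaps of the earlier compounds, with no separation from any of them (a 1.7-fold higher number from compound 3 to compound 4 (0.24 log units; within the scatter); a 1.1-fold higher number from compound 2 to compound 4 (0.03 log units; within the scatter); a 1.2-fold higher number from compound 1 to compound 4 (0.07 log units; within the scatter)). The 3,5-dibromo-4-hydroxyphenyl group brings bromine and a hydrogen-bond donor, which the 4-methoxyphenyl group lacks, and compound 4 still cannot be told apart from the rest of the series. No supporting data are available to explain this flat reading.

As far as these compounds go, it remains open whether a cyclohexyl group or a longer alkyl chain at this position, or an aromatic ring carrying an amine or a carboxylic acid, would give a step beyond the scatter. From the compounds shown here alone, how a lone bromo or a lone hydroxy group on the ring would read also remains open.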